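This account rests on a few compounds, and the source may have more. Where it says the series, first, only, none or still open, it means among the compounds named here.

Working notes on the series. Among the measured compounds shown here, in a functional assay on cells for antagonist activity at Free fatty acid receptor 1 (Homo sapiens), read by TR-FRET and inositol phosphate accumulation, with a stated time of 2 h (on this read-out lower numbers stand for stronger inhibition and higher numbers for weaker inhibition), compound 1 `Cc1cc(COc2ccc(Cl)cc2)nc(-c2ccccn2)n1` gives 251 nM, the only plain number in hand. For the measured compounds named here, compound 2 `CC(=O)Nc1ccccc1OCc1cc(C)nc(-c2ccccn2)n1` reaches only a limit in this assay, > 39800 nM, so no step within the measured pair can be sized; compound 1 stands alone as the reference. Compound 3 `Cc1cc(COc2ccc(S(C)(=O)=O)cc2)nc(-c2ccccn2)n1` differs from compound 1 by methylsulfonyl in place of chloro on an aromatic carbon. Going by the values given here, no measured step covers this change, so the expectation rests on the structural change alone: a step toward weaker inhibition, beyond the scatter, is expected, a 6.0-fold higher number from compound 1 to compound 3 (0.78 log units; beyond the scatter). For compound 3 in this assay the estimate is 1500 nM, within 300 nM to 10000 nM.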

Compound 3, half-maximal inhibitory concentration: > 39800 nM
Compound 3 gave a limit, no number; the forecaster's own chance of this, stated with the estimate: 20%; middle value at least 26-fold (1.42 log units) away from the limit.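

In this assay, methylsulfonyl in place of chloro on an aromatic carbon, para to a large group, gives an at least 150-fold higher number from compound 1 to compound 3 (2.20 log units; beyond the scatter). Compound 3 gives a limit, not a number, so this step is sized only from that limit: the limit of > 39800 nM in this assay, at which 2 of the 3 values shown sit. At this position, chloro goes with a measurable number, while methylsulfonyl does not. The compounds shown leave open how a fluoro, a methoxy or a carboxylic acid would read at this position. They also leave open whether methylsulfonyl alone is the exception or chloro is the unusual case.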